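A Pyridine Nitrogen Enters the Tetrahydroisoquinoline Amide

The source may hold more compounds than are shown below. What is called first, only, known or untested is meant among the compounds shown, and "the series" means these compounds.

Compound 1 `CC(C(=O)N1C[C@H]2CCC[C@H]2C1)N1CCN(S(=O)(=O)c2ccc(C(C)(C)C)cc2)CC1`: in an ADME assay on HepG2 cells (Homo sapiens) for inhibition, with a stated time of 48 h (on this read-out higher numbers stand for an effect only at larger amounts of compound and lower numbers for an effect already at smaller amounts), compound 1 gives > 40000 nM, a limit of the assay.
Compound 2 `CC(C(=O)N1Cc2ccccc2C1)N1CCN(S(=O)(=O)c2ccc(C(C)(C)C)cc2)CC1`: in this assay compound 2 gives > 40000 nM, also a limit.
Compound 3 `CC(C(=O)N1CCc2ccccc2C1)N1CCN(S(=O)(=O)c2ccc(C(C)(C)C)cc2)CC1`: in this assay compound 3 gives 29000 nM.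

Among the measured compounds shown here, compound 3 thus stands as the only actual number among the three results; the other two sit at a limit (the limit of > 40000 nM in this assay, at which 2 of the 3 values shown sit). Compound 4 `CC(C(=O)N1CCc2cccnc2C1)N1CCN(S(=O)(=O)c2ccc(C(C)(C)C)cc2)CC1` arises from compound 3 by a group of 10 heavy atoms (8 carbon, 2 nitrogen; one six-membered non-aromatic ring with 1 hetero atom, one six-membered aromatic ring with 1 hetero atom) in place of a group of 10 heavy atoms (9 carbon, 1 nitrogen; one six-membered non-aromatic ring with 1 hetero atom, one six-membered aromatic ring of carbon only), on a carbonyl carbon. For the measured compounds named here, no measured step swaps an aromatic carbon for a nitrogen in this way. The readable steps, an at least 1.3-fold lower number from compound 1 to compound 3 (0.13 log units; that floor lies within the scatter) and an at least 1.3-fold lower number from compound 2 to compound 3 (0.13 log units; that floor lies within the scatter), alter the size and shape of the saturated ring instead, and both stay within the scatter. The step to compound 4 is therefore expected to remain within the scatter, a 1.2-fold higher number from compound 3 to compound 4 (0.08 log units; within the scatter). Compound 4 is expected to give 35000 nM, between 15000 nM and 80000 nM, with a real chance that the assay again returns only a limit.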

Compound 4, half-maximal effective concentration: > 40000 nM
Compound 4: no number, only a limit; the forecaster's own chance of this, stated with the estimate: 45%; middle value at least 1.1-fold (0.05 log units) away from the limit.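

Replacing an aromatic ring carbon of the 1,2,3,4-tetrahydroisoquinolin-2-yl group with nitrogen, which adds a hydrogen-bond acceptor, gives an at least 1.3-fold higher number from compound 3 to compound 4 (0.13 log units; that floor lies within the scatter) in this assay. Among the compounds shown here, the earlier readable steps changed the saturated ring, so this is the first sign that a change in the aromatic ring also shows no step beyond the scatter. Compound 4 gives only a limit, and its steps from compound 1 and compound 2 cannot be read: the limit of > 40000 nM in this assay, at which 3 of the 4 values shown sit.

On these data alone, the true size of the step to compound 4 stays open. So does whether an amine or a methoxy group on that aromatic ring would give a step beyond the scatter.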